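This account rests on a few compounds, and the source may have more. Where it says the series, first, only, none or still open, it means among the compounds named here.

The measured compounds: compound 1 `CC(C)(C)OC(=O)N1CCC(O[C@H]2CC[C@H](Oc3ccc(S(C)(=O)=O)cc3)CC2)CC1`, which in a functional assay on isolated protein for agonist activity at Glucose-dependent insulinotropic receptor (Homo sapiens), read by HTRF and cAMP accumulation (on this read-out higher numbers stand for an effect only at larger amounts of compound and lower numbers for an effect already at smaller amounts), gives 16.1 nM; compound 2 `CC(C)(C)OC(=O)N1CCC(O[C@H]2CC[C@H](Oc3ccc(S(C)(=O)=O)c(F)c3)CC2)CC1`, which in this assay gives 52 nM; compound 3 `CC1(OC(=O)N2CCC(O[C@H]3CC[C@H](Oc4cnc(S(C)(=O)=O)cn4)CC3)CC2)CC1`, which in this assay gives 25.9 nM.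

Compound 3 holds the second highest of these three numbers; its nearest neighbour is compound 1, and compound 2 stands a little further off, both within the scatter, so no order can be read among the three. Among the compounds with values here, the only single-point step, a 3.2-fold higher number from compound 1 to compound 2 (0.51 log units; beyond the scatter), concerns a fluoro on an aromatic carbon. Compound 4 `CS(=O)(=O)c1cnc(O[C@H]2CC[C@H](OC3CCN(C(=O)C4(C(F)(F)F)CCCC4)CC3)CC2)cn1` differs from compound 3 elsewhere: a group of 9 heavy atoms (6 carbon, 3 fluorine; one five-membered non-aromatic ring of carbon only) in place of a group of 5 heavy atoms (4 carbon, 1 oxygen; one three-membered non-aromatic ring of carbon only), on a carbonyl carbon. Within the data shown here, no measured step touches that carbonyl carbon, so the fluoro step offers no guide, and compound 4 is expected to stay near compound 3 with a wide range, a 1.2-fold higher number from compound 3 to compound 4 (0.06 log units; within the scatter). Compound 4 is therefore estimated at 30 nM, between 8 nM and 120 nM.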

Compound 4, half-maximal effective concentration: 38.4 nM
Beside the measured number, compound 4's estimate is 1.3-fold (0.11 log units) below it; the range from low to high includes it.
By their numbers in this assay, from the lowest: compounds 1, 3, 4 and 2 (each within the scatter of the next, the first and the last beyond it).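

At the carbonyl carbon, this assay records a 1.5-fold higher number from compound 3 to compound 4 (0.17 log units; within the scatter) when the (1-methylcyclopropyl)oxy group gives way to the larger group with its five-membered carbon ring and three fluorines. This place therefore accepts a marked change in size and the loss of a hydrogen-bond acceptor from the group without a step beyond the scatter. Nothing available accounts for this result. Going by these compounds, whether an amine or a carboxylic acid in that group would leave the number as little changed stays open, as does how the fluoro step would read on the core of compound 4.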